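The source may report more compounds than this note shows. Statements on the series, on what has been measured and on what is new or still open speak of the compounds shown alone.

Compound 1 `COC(=O)c1c(-c2ccc(O)cc2)oc2ccc(OC)cc2c1=O` gives 18.7 ug/mL in a functional assay on SK-MEL cells (Homo sapiens) for cytotoxicity, read by MTT assay, with a stated time of 6 days; a lower number here means that less compound is needed, a higher number that more compound is needed for the effect. Compound 2 `COc1ccc2oc(-c3ccc(O)cc3)c(C(=O)O)c(=O)c2c1` gives only a limit of > 25 ug/mL in this assay. Compound 3 `COc1cc(-c2cc(=O)c3ccc(O)cc3o2)cc(OC)c1OC` likewise gives only a limit of > 25 ug/mL in this assay. For the measured compounds named here, the single counted change among the measured compounds, (methyl in place of hydrogen on an oxygen next to a carbonyl group), gives an at least 1.3-fold lower number from compound 2 to compound 1 (0.12 log units; that floor lies within the scatter); the floor on that step rests on (the limit of > 25 ug/mL in this assay, at which 2 of the 3 values shown sit). Compound 4 `COc1ccc2c(=O)cc(-c3cc(OC)c(OC)c(OC)c3)oc2c1` is not yet measured in this assay. It differs from compound 3 by methyl in place of hydrogen on an oxygen on an aromatic ring, the same kind of change as that from compound 2 to compound 1 but not the same: there the oxygen sits next to a carbonyl group, with a carbonyl carbon as its other neighbour, whereas here the oxygen sits on an aromatic ring, with an aromatic carbon as its other neighbour. The difference between the core of compound 3 and the core of compound 2 is not broken down here. With compound 3 at a limit and the earlier step only an at least 1.3-fold lower number from compound 2 to compound 1 (0.12 log units; that floor lies within the scatter), a small step is expected, an at least 1.1-fold lower number from compound 3 to compound 4 (0.05 log units; that floor lies within the scatter). Compound 4 is estimated at 22 ug/mL, between 10 ug/mL and 45 ug/mL, and may again return only a limit.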

Compound 4, concentration for half-maximal effect: > 25 ug/mL
Compound 4 was reported as a limit; the forecaster's own chance of this, stated with the estimate: 55%; at least 1.1-fold (0.05 log units) between middle value and limit.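

Compound 3 and compound 4 both stand only at a limit in this assay, so no step can be read for methyl in place of hydrogen on an oxygen on an aromatic ring: the limit of > 25 ug/mL in this assay, at which 3 of the 4 values shown sit.

The compounds shown leave open whether hydroxy to methoxy at this place changes the number at all in this assay.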